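A few compounds are considered here, and "the series" means these few. Any claim that something is new, unique, unknown or untested is made for them only; others in the source may bear on it.

The study concerns two measured compounds and one not yet measured, all built on a shared core. Compound 1 `CCCn1c(=O)n(CCCOC)c(=O)c2[nH]cnc21` carries a propyl and a methoxypropyl group on that core, and in an assay on Cerebral cortex for binding affinity to adenosine receptor A1 (Cavia porcellus), read by radioligand binding (on this read-out lower numbers stand for stronger inhibition and higher numbers for weaker inhibition), compound 1 gives 12400 nM. Compound 2 `CCCn1c(=O)n(C)c(=O)c2c1ncn2CC(N)=O` carries a propyl, a methyl and a carbamoylmethyl group. In this assay compound 2 gives only > 200000 nM, a limit of the assay rather than a number. For compound 2 the reading is therefore (the limit of > 200000 nM in this assay, at which 1 of the 2 values shown sits). Compound 3 `CCCn1c(=O)n(C)c(=O)c2c1ncn2CCCN(C)C` differs from compound 2 by 2-(dimethylamino)ethyl in place of carbamoyl on a saturated chain carbon bound to an aromatic nitrogen. Within the data shown here, no measured step of this kind is available, and compound 2 offers only a limit as a starting point. The step from compound 2 to compound 3 in this assay is expected to be an at least 2.0-fold lower number from compound 2 to compound 3 (0.30 log units; that floor lies within the scatter), a modest move toward stronger binding that may still lie within the scatter. Compound 3 is estimated at 100000 nM in this assay, with a range from 20000 nM to 500000 nM.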

Compound 3, inhibition constant: > 200000 nM
Compound 3 was reported as a limit (the forecaster's own chance of this, stated with the estimate: 45%); at least 2.0-fold (0.30 log units) between middle value and limit.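

In this assay compound 3 gives > 200000 nM, a limit of the assay and not a number, and compound 2 also stands at a limit, so no step can be read between compound 2 and compound 3: the limit of > 200000 nM in this assay, at which 2 of the 3 values shown sit.

The compounds shown leave open whether 2-(dimethylamino)ethyl in place of carbamoyl changes binding at all.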